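The source may hold more compounds than are shown below. What is called first, only, known or untested is meant among the compounds shown, and "the series" means these compounds.

Compound 1, `O=C(Nc1nc(-c2cc3ccccc3o2)cs1)Nc1ccccc1F`, in this assay: 2630 nM
Compound 2, `COc1ccc(NC(=O)Nc2nc(-c3cc4ccccc4o3)cs2)cc1`, in this assay: 17400 nM
Compound 3, `O=C(Nc1nc(-c2cc3cc(Br)ccc3o2)cs1)Nc1ccccc1F`, in this assay: a limit only, > 200000 nM

The three measured compounds share one core and differ at two places. In a physicochemical assay, with a stated time of 6 min (on this read-out higher numbers stand for weaker inhibition and lower numbers for stronger inhibition), compound 1 gives 2630 nM. Compound 2 carries 4-methoxyphenyl in place of 2-fluorophenyl on an amide-type nitrogen and in this assay compound 2 gives 17400 nM, a step of a 6.6-fold higher number from compound 1 to compound 2 (0.82 log units; beyond the scatter). Compound 3 carries bromo in place of hydrogen on an aromatic carbon, so its core differs from the core of compound 1 in that one place. For compound 3 this assay reports no number but a limit, > 200000 nM, which is the limit of > 200000 nM in this assay, at which 1 of the 3 values shown sits. The step from compound 1 to compound 3 is accordingly only bounded: an at least 76-fold higher number from compound 1 to compound 3 (1.88 log units; beyond the scatter).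

Compound 4, `COc1ccc(NC(=O)Nc2nc(-c3cc4cc(Br)ccc4o3)cs2)cc1`, has not yet been measured in this assay. It differs from compound 3 by 4-methoxyphenyl in place of 2-fluorophenyl on an amide-type nitrogen. This is the same change as that between compound 1 and compound 2, made here on the core of compound 3 rather than on that of compound 1, the two cores differing as said. When that change was made on compound 1 the number went up, a 6.6-fold higher number from compound 1 to compound 2 (0.82 log units; beyond the scatter). Compound 3 already sits at the limit of this assay, so compound 4 is expected to remain beyond it, with an expected step that the limit leaves unreadable from compound 3 to compound 4. The estimate for compound 4 in this assay is 1000000 nM, expected to lie between 200000 nM and 10000000 nM, and most probably reported again as a limit.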

Compound 4, half-maximal inhibitory concentration: > 200000 nM
Compound 4: only a limit was reported; the forecaster's own chance of this, stated with the estimate: 90%; the middle value lies beyond the limit too.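

In this assay compound 4 again gives no number but a limit, > 200000 nM, the same limit that compound 3 shows: the limit of > 200000 nM in this assay, at which 2 of the 4 values shown sit.

The step between these two bromo compounds cannot be read, so the swap of 2-fluorophenyl for 4-methoxyphenyl on the amide-type nitrogen, which gave a 6.6-fold higher number from compound 1 to compound 2 (0.82 log units; beyond the scatter), is neither confirmed nor refuted on the core of compound 3, and nothing can be said about whether its size or even its direction carries over. What can be read is the other change, bromo in place of hydrogen on an aromatic carbon, which gives an at least 11-fold higher number from compound 2 to compound 4 (1.06 log units; beyond the scatter) and so runs the same way as an at least 76-fold higher number from compound 1 to compound 3 (1.88 log units; beyond the scatter), though both steps are bounded only and their true sizes cannot be compared.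

The compounds shown leave open how far beyond the limit compound 3 and compound 4 actually lie, and whether any group on the amide-type nitrogen could bring a bromo compound back to a readable number. They also leave open what an amine or a carboxylic acid on that aromatic carbon, or a longer chain on the amide-type nitrogen, would give in this assay.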